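The compounds below may be only part of what the source reports. "The series", "measured", "known", "first", "only" and "open" are said of these compounds alone.

Working notes on the series. Compound 1 `O=C(CSc1snnc1-c1ccc(Br)cc1Br)Nc1cccnc1Cl` carries the shared core with 2-chloropyridin-3-yl on the amide-type nitrogen. In an ADME assay on MT4 cells (Homo sapiens) for cytotoxicity, read by MTT assay, with a stated time of 5 days (a lower number here means that less compound is tolerated, a higher number that more compound is tolerated), compound 1 reaches only a limit, > 240000 nM, and not a number (the limit of > 240000 nM in this assay, at which 1 of the 2 values shown sits). Among the compounds with values here, compound 2 `O=C(CSc1snnc1-c1ccc(Br)cc1Br)Nc1nccs1` holds 1,3-thiazol-2-yl there, and in this assay compound 2 gives 87800 nM, the only measured number so far. That exchange gave an at least 2.7-fold lower number from compound 1 to compound 2 (0.43 log units; beyond the scatter). Compound 3 `O=C(CSc1snnc1-c1ccc(Br)cc1Br)Nc1ccccc1Br` differs by 2-bromophenyl in place of 1,3-thiazol-2-yl on an amide-type nitrogen. Within the data shown here, only that one step bears on it; it ran towards a lower number on going to the five-membered heteroaryl, so the move back to a ring of carbon only is expected to run the other way in this assay. Compound 3 is therefore estimated at 160000 nM, range 60000 nM to 300000 nM. The expected step is a 1.8-fold higher number from compound 2 to compound 3 (0.26 log units; within the scatter).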

Compound 3, half-maximal cytotoxic concentration: > 221000 nM
Compound 3: only a limit was reported; the forecaster's own chance of this, stated with the estimate: 40%; middle value at least 1.3-fold (0.14 log units) from the limit.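

In this assay, 2-bromophenyl on the amide-type nitrogen gives an at least 2.5-fold higher number from compound 2 to compound 3 (0.40 log units; beyond the scatter) and so puts compound 2, with 1,3-thiazol-2-yl, beyond the scatter below both other compounds. Compound 3 reaches only a limit, not a number: the limit of > 221000 nM in this assay, at which 1 of the 3 values shown sits. With compound 1 also only a limit, the step between these two compounds cannot be read.

On these data alone, how far either compound sits from its limit remains open. Also open, as far as these compounds go, is what a carboxylic acid or a longer alkyl chain on the amide-type nitrogen would give in this assay.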